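Removing a chloro group on a fused dichloro core

The source may report more compounds than this note shows. Statements on the series, on what has been measured and on what is new or still open speak of the compounds shown alone.

Three compounds share a two-ring core carrying a chloro-substituted benzyl arm and differ only in the pattern of chloro groups on the core. In a functional assay on BT-549 cells (Homo sapiens) for cytotoxicity, read by sulforhodamine B assay, with a stated time of 48 h (a lower number here means a stronger inhibitor of growth, a higher number a weaker inhibitor of growth), compound 1 `ClCc1ccc(Cn2cnc3c(Cl)ncnc32)cc1` gives 5620 nM, compound 2 `ClCc1ccc(Cn2cnc3nc(Cl)nc(Cl)c32)cc1` gives 1860 nM, and compound 3 `ClCc1ccc(Cn2cnc3c(Cl)nc(Cl)nc32)cc1` gives 15900 nM. Compound 2 and compound 3 carry the same atoms joined differently; the difference between the two cores is not broken down here. One change has been measured: hydrogen in place of chloro on an aromatic carbon, which moved the number a 2.8-fold lower number from compound 3 to compound 1 (0.45 log units; beyond the scatter).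

Compound 4 `ClCc1ccc(Cn2cnc3ncnc(Cl)c32)cc1` has not yet been measured in this assay. It arises from compound 2 by the same change, (hydrogen in place of chloro on an aromatic carbon), at a place described in the same words as for the earlier pair. The expectation for compound 4 is a step of a 1.9-fold lower number from compound 2 to compound 4 (0.27 log units; within the scatter), a little smaller than the earlier one because compound 2 as starting point gives 1860 nM, the lowest of the three, and the earlier step rested on a single pair. Compound 4 is therefore estimated at 1000 nM, most likely falling between 350 nM and 3000 nM.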

Compound 4, concentration for 50% growth inhibition: 3710 nM
For compound 4 the middle estimate is 3.7-fold (0.57 log units) below the measured one; measured number above the stated range.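

In this assay, putting hydrogen in place of chloro on an aromatic carbon of the core of compound 2 gives a 2.0-fold higher number from compound 2 to compound 4 (0.30 log units; within the scatter), so on this core the change cannot be told apart from the ordinary spread of repeated measurements. Set beside the earlier pair, the same change does not carry over as one fixed step from one core to the other: the same change on two cores in this assay, a 2.8-fold lower number (0.45 log units; beyond the scatter) from compound 3 to compound 1 and a 2.0-fold higher number (0.30 log units; within the scatter) from compound 2 to compound 4, 5.6-fold (0.75 log units) apart, beyond the scatter of two such steps This shows that a step measured on one of these cores is a poor guide to the step on the other, but two pairs give no reason for the gap and no rule for any further core.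

The compounds shown carry only chloro or hydrogen at the aromatic carbon that changes, leaving open how an amine, a methoxy group or a longer carbon chain would behave there. On these data alone, all of them also keep the same chloro-substituted benzyl arm, so the effect of replacing its chloro with a hydroxyl group or an amine remains unknown.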